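The source may hold more compounds than are shown below. What is called first, only, known or untested is meant among the compounds shown, and "the series" means these compounds.

Measured in an ADME assay on MT4 cells (Homo sapiens) for cytotoxicity, read by MTT assay, with a stated time of 5 days; on this read-out higher numbers stand for lower toxicity in this test and lower numbers for higher toxicity in this test:

Compound 1 `Cc1cc(C)nc(Sc2ccnc(Nc3ccc(C#N)cc3)n2)n1` gives 224000 nM.
Compound 2 `N#Cc1ccc(Nc2nccc(OCc3ccc(Br)cc3)n2)cc1` gives 16000 nM.
Compound 3 `N#Cc1ccc(Nc2nccc(OCc3cccc(C(F)(F)F)c3)n2)cc1` gives 118000 nM.

Of these three numbers, compound 2 stands lowest in this assay, which on this read-out means the highest toxicity of the set. The nearest to it is compound 3, whose number is higher by a gap that lies beyond the usual scatter; compound 1 is further away still, again beyond the scatter. Compound 2 is therefore the clearly most toxic of the three measured compounds in this test.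

Compound 4 `N#Cc1ccc(Nc2nccc(OCc3ccc(Br)cc3F)n2)cc1` differs from compound 2 in one place: fluoro in place of hydrogen on an aromatic carbon. For the measured compounds named here, no pair of measured compounds shows what such a change does in this assay, so the expectation rests on the size of the change alone. With one heavy atom entering and nothing else altered, the step from compound 2 to compound 4 is expected to be small, a 1.1-fold lower number from compound 2 to compound 4 (0.06 log units; within the scatter), not beyond the scatter in either direction. Compound 4 is accordingly expected to give about 14000 nM, within a range from 5000 nM to 40000 nM.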

Compound 4, half-maximal cytotoxic concentration: 141000 nM
Compound 4: the middle estimate sits 10-fold (1.00 log units) below what was measured, and the stated range ends below it.
By their numbers in this assay, from the lowest: compound 2; then compounds 3, 4 and 1 (each within the scatter of the next).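

Going from 4-bromophenyl to 4-bromo-2-fluorophenyl in this assay gives an 8.8-fold higher number from compound 2 to compound 4 (0.95 log units; beyond the scatter), so this position, ortho to a large group and meta to a bromo group, responds clearly to the entry of a single fluorine atom. On this read-out, the step points to lower toxicity in this test, although it rests on this one pair of compounds. Nothing measured here accounts for the size of the step.

As far as these compounds go, whether a chloro, methyl or methoxy group at the same place would move the number in the same direction remains open, as does whether the effect is specific to fluoro. From the compounds shown here alone, it is also open whether the step depends on the bromo group, which a plain 2-fluorophenyl group would help to settle.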